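The compounds below may be only part of what the source reports. "The series", "measured", "known", "first", "only" and "open" are said of these compounds alone.

Measured so far in a functional assay for antagonist activity at Neuropeptide Y receptor type 2 (Homo sapiens); on this read-out lower numbers stand for stronger inhibition and higher numbers for weaker inhibition:
compound 1 `OC(c1ccccc1)(c1ccccc1)C1CCN(C(=S)Nc2ccc(OC(F)(F)F)cc2)CC1` — compound 1 gives 1050 nM
compound 2 `CCCc1ccc(NC(=S)N2CCC(C(O)(c3ccccc3)c3ccccc3)CC2)cc1` — compound 2 gives 777 nM
compound 3 `CCNC(=O)c1ccc(NC(=S)N2CCC(C(O)(c3ccccc3)c3ccccc3)CC2)cc1` — compound 3 gives 206 nM

Compound 3 stands at the lowest number of the three: a 5.1-fold lower number from compound 1 to compound 3 (0.71 log units; beyond the scatter) and a 3.8-fold lower number from compound 2 to compound 3 (0.58 log units; beyond the scatter) both run beyond the scatter, whereas a 1.4-fold lower number from compound 1 to compound 2 (0.13 log units; within the scatter) does not. Compound 4 `CCOc1ccc(NC(=S)N2CCC(C(O)(c3ccccc3)c3ccccc3)CC2)cc1C#N` has not been measured. The change from compound 3 is 3-cyano-4-ethoxyphenyl in place of 4-(ethylcarbamoyl)phenyl on an amide-type nitrogen. For the measured compounds named here, no measured step makes this exact exchange. Going by the values given here, the steps that bear on it are those that end at compound 3, a 5.1-fold lower number from compound 1 to compound 3 (0.71 log units; beyond the scatter) and a 3.8-fold lower number from compound 2 to compound 3 (0.58 log units; beyond the scatter), which show that the ethylcarbamoyl group, the only one of the three carrying a hydrogen-bond donor on that ring, goes with the lowest number, while compound 1 and compound 2, without such a donor, sit within the scatter of each other at higher numbers. Compound 4 likewise carries no donor on that ring, so a step back up toward those numbers is expected, of roughly the size of a 2.9-fold higher number from compound 3 to compound 4 (0.46 log units; beyond the scatter) in this assay. Compound 4 is therefore estimated at 600 nM, with a range from 250 nM to 1500 nM.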

Compound 4, half-maximal inhibitory concentration: 323 nM
Estimate against measurement, compound 4: 1.9-fold (0.27 log units) above; measured number inside the range.
By their numbers in this assay, from the lowest: compounds 3 and 4 (each within the scatter of the next); then compounds 2 and 1 (each within the scatter of the next).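

In this assay, a 1.6-fold higher number from compound 3 to compound 4 (0.20 log units; within the scatter) stays within the scatter, so on this amide-type nitrogen the 3-cyano-4-ethoxyphenyl group, with 0 hydrogen-bond donors, cannot be told apart from the 4-(ethylcarbamoyl)phenyl group, which has 1. For the compounds shown here, the lower numbers at this position therefore do not require a donor on the ring: a 2.4-fold lower number from compound 2 to compound 4 (0.38 log units; beyond the scatter) and a 3.3-fold lower number from compound 1 to compound 4 (0.51 log units; beyond the scatter) both run beyond the scatter, and compound 4 goes against the link between a donor and a lower number suggested by the earlier compounds. No available evidence accounts for these steps.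

Compound 4 carries the nitrile and the ethoxy together, so the share of each in these steps remains unresolved. Also open, as far as these compounds go, is how a carboxylic acid or a primary amine on this ring would read out.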